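This account rests on a few compounds, and the source may have more. Where it says the series, first, only, none or still open, it means among the compounds named here.

Compound 3 `CC(C)(O)CCN1CCC(NS(=O)(=O)c2cc(S(=O)(=O)c3ccccc3)ccc2C(F)(F)F)CC1` stands at > 100000 nM in a physicochemical assay for solubility, at pH 7.4 (a lower number here means a less soluble compound, a higher number a more soluble compound), and that reading is a limit of the assay, not a number. Compound 1 `O=C(c1cccnc1)N1CCC(NS(=O)(=O)c2cc(S(=O)(=O)c3ccccc3)ccc2C(F)(F)F)CC1` gives 78000 nM in this assay and compound 2 `O=C(c1ccc(Cl)nc1)N1CCC(NS(=O)(=O)c2cc(S(=O)(=O)c3ccccc3)ccc2C(F)(F)F)CC1` gives 1700 nM on the same read-out. Compound 4 `O=C([C@@H]1CCNC1)N1CCC(NS(=O)(=O)c2cc(S(=O)(=O)c3ccccc3)ccc2C(F)(F)F)CC1` carries (pyrrolidin-3-yl)carbonyl in place of 3-hydroxy-3-methylbutyl on an amine nitrogen in a ring. Bearing on this, the change an at least 1.2-fold higher number from compound 1 to compound 3 (0.10 log units; that floor lies within the scatter) has its floor within the scatter, whereas an at least 58-fold higher number from compound 2 to compound 3 (1.76 log units; beyond the scatter) is large. The chloro step a 46-fold lower number from compound 1 to compound 2 (1.66 log units; beyond the scatter) is also large, and compound 4 has no chloro. Compound 4 carries a carbonyl on that nitrogen like compound 1 at 78000 nM so a small downward move or none beyond the scatter is expected. The expected step is an at least 1.1-fold lower number from compound 3 to compound 4 (0.07 log units; that floor lies within the scatter) in this assay as estimated here. For compound 4 the estimate is 85000 nM with an expected range of 35000 nM to 100000 nM on this read-out.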

Compound 4, solubility: 70000 nM
Compound 4: the middle estimate sits 1.2-fold (0.08 log units) above what was measured, within the range that was stated.
By their numbers in this assay, from the lowest: compound 2; then compounds 4 and 1 (each within the scatter of the next). At a limit, above all of these: compound 3.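

On the carbonyl carbon, pyrrolidin-3-yl in place of pyridin-3-yl gives a 1.1-fold lower number from compound 1 to compound 4 (0.05 log units; within the scatter), so the two groups cannot be told apart in this assay. An aromatic ring on that carbonyl is therefore not required for a high reading among these amides, and compound 2, with its 6-chloropyridin-3-yl, stands apart: a 41-fold higher number from compound 2 to compound 4 (1.61 log units; beyond the scatter). The reading of compound 3 is a limit: the limit of > 100000 nM in this assay, at which 1 of the 4 values shown sits. The step from it can be given only as a floor: an at least 1.4-fold lower number from compound 3 to compound 4 (0.15 log units; that floor lies within the scatter).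

On these data alone, it remains open how a morpholine or a carboxylic acid in place of pyrrolidin-3-yl would read. As far as these compounds go, the opposite stereocentre of the pyrrolidine also remains open.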